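Aryl swap on the ring nitrogen: working notes

This account rests on a few compounds, and the source may have more. Where it says the series, first, only, none or still open, it means among the compounds named here.

compound 1, `N#CC1=C(N)Oc2c(c3nc4ccccc4nc3c3ccccc23)C12C(=O)N(Cc1cnnn1-c1cccc(Cl)c1)c1ccccc12`: in a functional assay on HepG2 cells (Homo sapiens) for antiproliferative activity, read by MTT assay, with a stated time of 48 h (a higher number here means a weaker inhibitor, a lower number a stronger inhibitor), compound 1 gives > 50000 nM, a limit of the assay and not a number.
compound 2, `N#CC1=C(N)Oc2c(N)cc3nc4ccccc4nc3c2C12C(=O)N(Cc1cnnn1-c1ccc(F)cc1)c1ccccc12`: in this assay compound 2 gives > 50000 nM, again a limit and not a number.

Among the measured compounds shown here, compound 2 therefore stands on no number at all: the only value shown for it is a limit, and the one further value in the set is a limit as well, (the limit of > 50000 nM in this assay, at which 2 of the 2 values shown sit). For the measured compounds named here, no pair of measured compounds differing in a single place exists, so there is no measured step to say how a change at the aryl on the five-membered aromatic ring with three nitrogens moves this read-out.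

Compound 3, `CCc1cccc(CC)c1-n1nncc1CN1C(=O)C2(C(C#N)=C(N)Oc3c(N)cc4nc5ccccc5nc4c32)c2ccccc21`, differs from compound 2 by 2,6-diethylphenyl in place of 4-fluorophenyl on an aromatic nitrogen.

With both shown values sitting at the limit, there is no footing in this assay for expecting a move beyond the scatter in either direction. The step expected here, a number no higher from compound 2 to compound 3 (the limit leaves the size open), is taken as none beyond the scatter, with a limit the most likely outcome. Compound 3 is estimated at 50000 nM, within a range from 15000 nM to 200000 nM.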

Compound 3, half-maximal inhibitory concentration: 16500 nM
The estimate for compound 3 lay 3.0-fold (0.48 log units) above the measured number, within the range that was stated.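

In this assay, the aryl on the aromatic nitrogen of the five-membered aromatic ring with 3 nitrogen now proves to be a place where a single change can move the read-out: 2,6-diethylphenyl in place of 4-fluorophenyl gives an at least 3.0-fold lower number from compound 2 to compound 3 (0.48 log units; beyond the scatter). This is the only measured step shown in the series, and compound 3, at 16500 nM, is the only compound shown with a number and not a limit. The size of the step stays open on one side, since compound 2 stands only on a limit of the assay: the limit of > 50000 nM in this assay, at which 2 of the 3 values shown sit.

With one step, the two parts of this change cannot be separated, so the loss of the 4-fluoro group and the arrival of the two ethyl groups may each account for any part of it. Plain phenyl, 2,6-dimethylphenyl and 4-ethylphenyl at the same place would tell these parts apart, while compound 1 differs from compound 3 in more than one place and offers no comparison.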